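Amide substituent change and acid dissociation in the series

A few compounds are considered here, and "the series" means these few. Any claim that something is new, unique, unknown or untested is made for them only; others in the source may bear on it.

Of the compounds shown here, two carry a measured number so far. In a physicochemical assay for acid dissociation, compound 1 `CC(C)N1CCC(Oc2ccc3nc(C(=O)N4CCC4)ccc3c2)CC1` gives 9.5. In this assay compound 2 `COC1CCN(C(=O)c2ccc3cc(OCCCN4CCCCC4)ccc3c2)CC1` gives 9.57. Compound 1 stands as the lower of the two numbers, but compound 2 lies within the usual scatter of it, so no order between the two can be read from these values.

Compound 3 `CC(C)N1CCC(Oc2ccc3nc(C(=O)N4CCC[C@H]4C#N)ccc3c2)CC1` differs from compound 1 in one place: 2-cyanopyrrolidin-1-yl in place of azetidin-1-yl on a carbonyl carbon. The rest of the shared core of compound 1 is kept unchanged. For the measured compounds named here, no step between measured compounds of this kind exists, so the size of the step cannot be read from the data at hand. The step of a number 0.05 log units lower from compound 1 to compound 3 (within the scatter) is expected to be no larger than the scatter, with no clear direction. Compound 3 is therefore estimated at 9.45, with a range from 9.05 to 9.85.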

Compound 3, acid dissociation constant: 9.5
Estimate against measurement, compound 3: 0.05 log units below, and the stated range covers the measured number.
By their numbers in this assay, from the lowest: compounds 1, 3 and 2 (each within the scatter of the next).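

In this assay, the first step read at this position, 2-cyanopyrrolidin-1-yl in place of azetidin-1-yl on a carbonyl carbon, gives no change at the digits printed from compound 1 to compound 3 (within the scatter). The entering group brings a five-membered ring, a triple bond, a hydrogen-bond acceptor and a defined stereocentre, and this exchange still leaves the number in this assay unmoved within the scatter. Nothing at hand bears on the reason for this result.

Open, from the compounds shown here alone, is whether a group carrying an amine or a carboxylic acid in place of azetidin-1-yl on this carbonyl carbon would move the number in this assay beyond the scatter. Also open, going by these compounds, is whether the mirror-image form of 2-cyanopyrrolidin-1-yl or an unsubstituted pyrrolidin-1-yl would read the same.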